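Removing the cyclopropyl from the weakest member of the series

The source may report more compounds than this note shows. Statements on the series, on what has been measured and on what is new or still open speak of the compounds shown alone.

Compound 1 `O=C1c2ccc(Cl)cc2C(C2CC2)N1c1cccnc1` is the weakest inhibitor among the three measured compounds: in an ADME assay on cells for inhibition of cytochrome P450 11B1, mitochondrial (Homo sapiens), read by HTRF (on this read-out higher numbers stand for weaker inhibition and lower numbers for stronger inhibition), compound 1 gives 32500 nM. Compound 2 `CCC(=O)N[C@@H]1CCCc2c1cncc2N1CCc2cc(Cl)ccc2C1=O` gives 3330 nM and compound 3 `CC[C@@H]1c2cc(Cl)ccc2C(=O)N1c1cncc2c1CCC[C@H]2NC(C)=O` gives 334 nM in this assay, both lower than compound 1 by more than the scatter of the method.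

Compound 4 `O=C1c2ccc(Cl)cc2CN1c1cccnc1` keeps the core of compound 1 and differs in one place: hydrogen in place of cyclopropyl on a saturated ring carbon. Among the compounds with values here, no measured pair shows this change, so its size is unknown. Since only a small group is removed from a compound that is already weak, a modest step toward weaker inhibition is expected, a 1.8-fold higher number from compound 1 to compound 4 (0.27 log units; within the scatter), and the value for compound 4 is estimated at 60000 nM, in the range 20000 nM to 180000 nM.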

Compound 4, half-maximal inhibitory concentration: 10700 nM
Compound 4: middle estimate off by 5.6-fold (0.75 log units), on the high side; the measured number lies below the stated range.
By their numbers in this assay, from the lowest: compound 3; then compound 2; then compound 4; then compound 1.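

In this assay hydrogen in place of cyclopropyl on this saturated ring carbon gives a 3.0-fold lower number from compound 1 to compound 4 (0.48 log units; beyond the scatter) and so moves toward stronger inhibition. Cyclopropyl at this position is therefore not required for inhibition on the core of compound 1, and compound 4 shows that removing it does not weaken inhibition. Within the data shown here, nothing measured so far accounts for the direction of this step.

Going by these compounds, whether a methyl, a longer chain or an amine on this carbon would give a lower or a higher number than hydrogen remains open. Also open, on these data alone, is whether the same change would move the number in the same direction on the cores of compound 2 and compound 3.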